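A Fluoro for Methoxy Swap in Compound 3

The source may report more compounds than this note shows. Statements on the series, on what has been measured and on what is new or still open speak of the compounds shown alone.

Of the compounds shown here, two built on a shared core have numbers so far. In a functional assay on SW480 cells (Homo sapiens) for antiproliferative activity, read by sulforhodamine B assay, with a stated time of 48 h (a higher number here means a weaker inhibitor, a lower number a stronger inhibitor), compound 1 `COc1cccc(/C=C/C(=O)C(=Cc2ccc(OC)c(OC)c2OC)C(=O)/C=C/c2cccc(OC)c2OC)c1OC` gives 560 nM, and compound 2 `COc1ccc(/C=C/C(=O)C(=Cc2ccc(O)c(OC)c2)C(=O)/C=C/c2ccc(OC)cc2OC)c(OC)c1` gives 1520 nM. Compound 2 therefore holds the higher of the two numbers, making it the weaker inhibitor, and its gap to compound 1 lies beyond the usual scatter. These two compounds differ in more than one place, so their gap does not isolate the effect of any single group.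

Compound 3 `COc1ccc(/C=C/C(=O)C(=Cc2ccc(O)c(F)c2)C(=O)/C=C/c2ccc(OC)cc2OC)c(OC)c1` departs from compound 2 in one place: fluoro in place of methoxy on an aromatic carbon. A 4-hydroxy-3-methoxyphenyl becomes a 3-fluoro-4-hydroxyphenyl, with fluoro in place of methoxy on an aromatic carbon, ortho to a hydroxy group and meta to a large group. Among the compounds with values here, no measured pair shows this change, so the direction remains uncertain. In this assay, no step beyond the scatter is expected, with only a slight lean toward a lower number. The expected change is a 1.2-fold lower number from compound 2 to compound 3 (0.07 log units; within the scatter). For compound 3, the estimated value is 1300 nM, with an expected range from 500 nM to 3500 nM.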

Compound 3, half-maximal inhibitory concentration: 3350 nM
Compound 3: middle estimate off by 2.6-fold (0.41 log units), on the low side; measured number inside the range.
By their numbers in this assay, from the lowest: compound 1; then compound 2; then compound 3.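

In this assay, putting fluoro in place of methoxy on this aromatic carbon, ortho to a hydroxy group and meta to a large group, gives a 2.2-fold higher number from compound 2 to compound 3 (0.34 log units; beyond the scatter). Within the data shown here, this is the first comparison that isolates a single change, and it shows that this position is not indifferent to the swap: the 4-hydroxy-3-methoxyphenyl of compound 2 gives the stronger inhibitor, and the 3-fluoro-4-hydroxyphenyl of compound 3 the weaker one, a point the gap between compound 1 and compound 2 could not settle. No measurement shown here bears on why the number rises with this change.

Still open, as far as these compounds go, is whether the rise belongs to the departure of the methoxy or to the arrival of the fluoro, a question that a chloro, an ethoxy or a plain hydrogen on the same carbon would help to separate. Also open, from the compounds shown here alone, is whether the same swap would move the number in the same direction with the other methoxy patterns on the shared core, such as those of compound 1.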